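A few compounds are considered here, and "the series" means these few. Any claim that something is new, unique, unknown or untested is made for them only; others in the source may bear on it.

In a functional assay on NCI-H1299 cells (Homo sapiens) for cytotoxicity, read by resazurin assay, with a stated time of 72 h (a higher number here means a weaker inhibitor, a lower number a stronger inhibitor), compound 1 `COc1cc(/C=C/C(=O)OCCCCCCO[N+](=O)[O-])ccc1O` gives > 50000 nM, which is a limit of the assay and not a number. Compound 1 therefore stands at the limit of > 50000 nM in this assay, at which 1 of the 2 values shown sits. The other tested compound, compound 2 `COc1cc(/C=C/C(=O)OCc2c(-c3ccccc3)no[n+]2[O-])ccc1O`, returns an actual number in this assay of 12900 nM. Compound 3 `COc1cc(/C=C/C(=O)OCCCO[N+](=O)[O-])ccc1O` keeps the core of compound 1 and changes only the chain, with nitrooxy in place of 3-(nitrooxy)propyl on a saturated chain carbon, three bonds along the chain from an oxygen next to a carbonyl group. Going by the values given here, no measured pair shows what a change of this kind does, so no step beyond the usual scatter is expected. The expected change is a number no higher from compound 1 to compound 3 (the limit leaves the size open) in this assay, and the result may well be a limit again. For compound 3 the estimate is 50000 nM, with an expected range from 20000 nM to 100000 nM.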

Compound 3, half-maximal inhibitory concentration: 28300 nM
For compound 3 the middle estimate is 1.8-fold (0.25 log units) above the measured one; measured number inside the range.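

In this assay, going by these compounds alone, the first measured pair for a change at this place, on a saturated chain carbon, three bonds along the chain from an oxygen next to a carbonyl group, gives an at least 1.7-fold lower number from compound 1 to compound 3 (0.24 log units; that floor lies within the scatter). Compound 1 stands at a limit of the assay, not at a number: the limit of > 50000 nM in this assay, at which 1 of the 3 values shown sits. The step is therefore only a floor, but compound 3 shows that the shared core with a shorter chain ending in nitrooxy can give a real number in this assay.

On these data alone, the true size of the step remains open, as does whether the number follows chain length in a smooth way, which a butyl chain ending in nitrooxy could test. Also open, as far as these compounds go, is how much the nitrooxy group itself contributes, which a plain propyl ester or a free carboxylic acid would address.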